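This account rests on a few compounds, and the source may have more. Where it says the series, first, only, none or still open, it means among the compounds named here.

Measured so far:
compound 1, `CNC(=O)c1cnc(C(=O)CCc2ccc(COc3ccccc3)cc2)o1`, 3.6 nM
compound 2, `O=C(CCc1ccc(-c2ccccc2)cc1)c1ncc(-c2cccnc2)o1`, 1.1 nM
compound 3, `COC(=O)c1cnc(C(=O)CCc2ccc(Oc3ccccc3)cc2)o1`, 1.7 nM

In an assay for inhibition of Fatty-acid amide hydrolase 1 (Rattus norvegicus) (a lower number here means a stronger inhibitor, a higher number a weaker inhibitor), compound 2 has the lowest number of the three. Compound 3 sits within the scatter of it, so the two cannot be told apart; compound 1 lies beyond the scatter, with the higher number. Compound 4, `O=C(O)c1ccc(-c2cnc(C(=O)CCc3ccc(-c4ccccc4)cc3)o2)nc1`, has not yet been measured. It differs from compound 2 by one change: 5-carboxypyridin-2-yl in place of pyridin-3-yl on an aromatic carbon. Among the compounds with values here, no measured pair shows this kind of change, so its effect is unknown. A modest weakening is expected, since the closest measured analogue compound 2 gives 1.1 nM and the added carboxylic acid is a larger alteration than the ester or amide seen elsewhere. The expected step from compound 2 to compound 4 is a 4.5-fold higher number from compound 2 to compound 4 (0.66 log units; beyond the scatter). Compound 4 is estimated at 5 nM, between 1.2 nM and 25 nM.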

Compound 4, inhibition constant: 14 nM
Compound 4: the middle estimate sits 2.8-fold (0.45 log units) below what was measured, and the stated range covers the measured number.
By their numbers in this assay, from the lowest: compounds 2 and 3 (each within the scatter of the next); then compound 1; then compound 4.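

In this assay, putting 5-carboxypyridin-2-yl in place of pyridin-3-yl on the aromatic carbon next to the ring oxygen gives a 13-fold higher number from compound 2 to compound 4 (1.10 log units; beyond the scatter), the first sign that this position responds to what it carries. Even so, compound 4 still gives 14 nM, so this larger group does not abolish inhibition. Nothing measured here explains the step.

As far as these compounds go, the ring attachment and the carboxylic acid change together, so their separate shares remain open. A plain pyridin-2-yl group at this position would separate them.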